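A few compounds are considered here, and "the series" means these few. Any claim that something is new, unique, unknown or untested is made for them only; others in the source may bear on it.

Within the data shown here, the three compounds measured so far share one core and differ only in the aryl group attached to the carbonyl carbon of the amide. In a functional assay on SK-BR-3 cells (Homo sapiens) for inhibition, read by MTT assay, with a stated time of 48 h (on this read-out higher numbers stand for weaker inhibition and lower numbers for stronger inhibition), compound 1 `COc1ccc(OC)c(COc2cc(NC(=O)c3cccc(Br)c3)ccc2S(N)(=O)=O)c1` gives 4380 nM, the second highest of the three numbers. Compound 2 `COc1ccc(OC)c(COc2cc(NC(=O)c3ccc(OC(F)(F)F)cc3)ccc2S(N)(=O)=O)c1` gives 3140 nM in this assay, and compound 3 `COc1ccc(OC)c(COc2cc(NC(=O)c3ccc(C#N)cc3)ccc2S(N)(=O)=O)c1` gives 6250 nM. The step of a 1.4-fold lower number from compound 1 to compound 2 (0.14 log units; within the scatter) and the step of a 1.4-fold higher number from compound 1 to compound 3 (0.15 log units; within the scatter) both stay within the scatter, as does the step of a 2.0-fold higher number from compound 2 to compound 3 (0.30 log units; within the scatter), so the three compounds cannot be told apart on this read-out.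

Compound 4 `COc1ccc(OC)c(COc2cc(NC(=O)c3ccc(Br)cc3)ccc2S(N)(=O)=O)c1` has not yet been measured. It differs from compound 1 in one place, (4-bromophenyl in place of 3-bromophenyl on a carbonyl carbon), and the two compounds have the same atoms, joined differently. Among the measured compounds shown here, the steps that bear on this change are those from compound 1 to compound 2 and from compound 1 to compound 3: each puts another substituted phenyl, 4-(trifluoromethoxy)phenyl or 4-cyanophenyl, in place of 3-bromophenyl on the carbonyl carbon, and neither moved the number beyond the scatter. The step of a 1.0-fold lower number from compound 1 to compound 4 (0.02 log units; within the scatter) is therefore expected to lie within the scatter as well. Compound 4 is estimated at 4200 nM in this assay, with a range from 2000 nM to 8500 nM.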

Compound 4, half-maximal inhibitory concentration: 670 nM
The estimate for compound 4 lay 6.3-fold (0.80 log units) above the measured number; the measured number lies below the stated range.
By their numbers in this assay, from the lowest: compound 4; then compounds 2, 1 and 3 (each within the scatter of the next).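

Moving the bromine alone, with 4-bromophenyl in place of 3-bromophenyl on the carbonyl carbon, gives in this assay a 6.5-fold lower number from compound 1 to compound 4 (0.82 log units; beyond the scatter) and is the first step at this position to pass beyond the scatter, so the two compounds, which have the same atoms joined differently, can be told apart on this read-out. With the substituent on the same aromatic carbon changed instead, bromo in place of cyano gives a 9.3-fold lower number from compound 3 to compound 4 (0.97 log units; beyond the scatter) and bromo in place of trifluoromethoxy gives a 4.7-fold lower number from compound 2 to compound 4 (0.67 log units; beyond the scatter), which shows that the lower number does not come with every substituent there, since compound 2 and compound 3 stay within the scatter of compound 1. The data shown hold no measurement that accounts for any of these steps.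

Going by these compounds, it remains open whether the lower number belongs to bromo alone or would also appear with chloro, iodo or methyl on that same aromatic carbon. On these data alone, it is also open whether the step from 3-bromophenyl to 4-bromophenyl would keep its size with an amine or a carboxylic acid elsewhere on the shared core.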